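Pyridin-2-yl in place of 4-methylphenyl: expected effect

A few compounds are considered here, and "the series" means these few. Any claim that something is new, unique, unknown or untested is made for them only; others in the source may bear on it.

Two members of the series have numbers. Compound 1 `Cc1nccn1CCC(O)(c1ccccc1)c1ccccc1` gives 16.7 nM in an assay on ileum with muscarinic acetylcholine receptor M3 (Cavia porcellus) as the target; on this read-out lower numbers stand for stronger inhibition and higher numbers for weaker inhibition. Compound 2 `Cc1ccc(C(CCn2ccnc2C)(C(N)=O)c2ccccc2)cc1` gives 24.6 nM in this assay; this is the higher of the two numbers, but the gap to compound 1 lies within the scatter, so the two compounds are not separated on this read-out. Going by the values given here, no pair of measured compounds differs in a single place, so no measured step is available to anchor an exchange of ring systems.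

Compound 3 `Cc1nccn1CCC(C(N)=O)(c1ccccc1)c1ccccn1` is not yet measured. It differs from compound 2 in one place: pyridin-2-yl in place of 4-methylphenyl on a saturated chain carbon bound to an aromatic carbon, a carbonyl carbon and a saturated chain carbon. The measured pair says nothing about an exchange of this kind, and the direction of the step is therefore open. Pending the measurement, the step expected in this assay is a 1.2-fold higher number from compound 2 to compound 3 (0.09 log units; within the scatter), a shift that is not expected to go beyond the usual scatter in either direction. Compound 3 is accordingly estimated at 30 nM in this assay, with a range from 8 nM to 110 nM that allows for a move of moderate size either way.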

Compound 3, antagonist equilibrium constant: 2.86 nM
Estimate against measurement, compound 3: 10-fold (1.02 log units) above; measured number below the stated range.
By their numbers in this assay, from the lowest: compound 3; then compounds 1 and 2 (each within the scatter of the next).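

Going by these compounds alone, at the saturated chain carbon bound to an aromatic carbon, a carbonyl carbon and a saturated chain carbon, the ring exchange registers clearly in this assay: pyridin-2-yl in place of 4-methylphenyl gives an 8.6-fold lower number from compound 2 to compound 3 (0.93 log units; beyond the scatter), the only single-place step so far and one beyond the scatter. This shows that the read-out responds to the identity of this ring, which the two earlier compounds could not show, but the exchange alters several things at once: 4-methylphenyl, with 7 heavy atoms and 0 hydrogen-bond acceptors, leaves, while pyridin-2-yl, with 6 heavy atoms, 1 nitrogen and 1 hydrogen-bond acceptor, enters, so this single step cannot apportion the gain among those differences. Nothing measured here gives a reason for the step.

An unsubstituted phenyl in place of the pyridin-2-yl would separate the part played by the ring nitrogen from the part played by the methyl, and pyridin-3-yl or pyridin-4-yl at the same place would test whether the nitrogen's location matters. As far as these compounds go, whether the step carries over to a carboxylic acid in place of the carboxamide also remains open.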